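The source may hold more compounds than are shown below. What is called first, only, known or untested is meant among the compounds shown, and "the series" means these compounds.

Measured compounds:
compound 1 `Cc1ccc(S(=O)(=O)/C(=C/c2cccs2)C(=O)c2ccc(Cl)cc2)cc1`, 25000 nM in a functional assay on DU-145 cells (Homo sapiens) for inhibition, read by trypan blue exclusion, with a stated time of 96 h; a lower number here means a stronger inhibitor of growth, a higher number a weaker inhibitor of growth
compound 2 `COc1cc(OC)c(/C=C(\C(=O)c2ccc([N+](=O)[O-])cc2)S(=O)(=O)Cc2ccc(Cl)cc2)c(OC)c1`, 10000 nM
compound 3 `O=C(/C(=C\c1ccc(F)cc1F)S(=O)(=O)c1ccc(Br)cc1)c1ccc(Br)cc1`, 7500 nM

Among these three, compound 1 gives the highest number, beyond the scatter from both compound 2 and compound 3, so on this evidence it is the weakest inhibitor of growth. No two of the measured compounds differ in only one place, so no single change can be read off directly.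

Compound 4 `Cc1ccc(S(=O)(=O)/C(=C/c2ccc(O)c([N+](=O)[O-])c2)C(=O)c2ccc(Cl)cc2)cc1` has not yet been measured. It differs from compound 1 in one place: 4-hydroxy-3-nitrophenyl in place of thiophen-2-yl on a double-bonded chain carbon bound to a double-bonded chain carbon. Compounds 2 and 3, which carry substituted six-membered aromatic rings at the same chain position, both give lower numbers than compound 1, so a step downward from compound 1 to compound 4 in this assay is expected, estimated at a 2.1-fold lower number from compound 1 to compound 4 (0.32 log units; beyond the scatter), of modest size. Compound 4 is therefore estimated at 12000 nM, with a range from 3000 nM to 40000 nM.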

Compound 4, concentration for 50% growth inhibition: 25000 nM
Compound 4: the middle estimate sits 2.1-fold (0.32 log units) below what was measured; low and high end bracket the measured number.
By their numbers in this assay, from the lowest: compounds 3 and 2 (each within the scatter of the next); then compounds 1 and 4 (each within the scatter of the next).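

In this assay, putting 4-hydroxy-3-nitrophenyl in place of thiophen-2-yl on a double-bonded chain carbon bound to a double-bonded chain carbon gives no change at the digits printed from compound 1 to compound 4 (within the scatter). At this position, then, exchanging the five-membered aromatic ring for a six-membered aromatic ring of carbon only, with a hydrogen-bond donor added, leaves growth inhibition unmoved. Nothing measured here bears on the reason for this. The compounds shown leave open how an unsubstituted phenyl, a 4-hydroxyphenyl or a 3-nitrophenyl would read at this position. They also leave open whether a pyridine ring or an amine there would give a different number.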